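A few compounds are considered here, and "the series" means these few. Any claim that something is new, unique, unknown or untested is made for them only; others in the source may bear on it.

Measured compounds:
- compound 1, `O=c1cc(-c2ccccc2)oc2ccc(N3COc4c(cccc4[N+](=O)[O-])C3)cc12`: 28400 nM
- compound 2, `Cc1cc(C)c2c(c1)CN(c1ccc3c(=O)cc(-c4ccccc4)oc3c1)CO2`: 61900 nM

Both compounds were tested in a functional assay on MCF7 cells (Homo sapiens) for inhibition, read by MTT assay, with a stated time of 48 h; a lower number here means a stronger inhibitor, a higher number a weaker inhibitor. Compound 1 gives 28400 nM, the lowest of the two numbers, and compound 2 gives 61900 nM, a gap between them that lies beyond the usual scatter. Going by the values given here, these two compounds differ in more than one place, so their two values show only that compound 1 is the stronger inhibitor of the pair, with nothing to say about which part of the structure is responsible.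

Compound 3, `O=c1cc(-c2ccccc2)oc2ccc(N3COc4c(Br)cccc4C3)cc12`, has not yet been measured. It differs from compound 1 in one place:
bromo in place of nitro on an aromatic carbon

Among the compounds with values here, there is no measured step between compounds that differ in a single place, so the size of this change cannot be read from the numbers at hand. The expectation for compound 3 in this assay is therefore a step of a 1.1-fold higher number from compound 1 to compound 3 (0.02 log units; within the scatter), within or close to the scatter and in no firm direction. The estimate for compound 3 is 30000 nM, expected to fall between 10000 nM and 90000 nM.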

Compound 3, half-maximal inhibitory concentration: 19600 nM
Compound 3: the middle estimate sits 1.5-fold (0.18 log units) above what was measured, and the stated range covers the measured number.
By their numbers in this assay, from the lowest: compounds 3 and 1 (each within the scatter of the next); then compound 2.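

In this assay, going by these compounds alone, replacing the nitro group with bromo on this aromatic carbon gives a 1.4-fold lower number from compound 1 to compound 3 (0.16 log units; within the scatter), the first comparison here in which only one place in the structure differs. The two groups are not alike on paper: nitro brings three heavy atoms, a double bond and two hydrogen-bond acceptors, whereas bromo is a single heavy atom with no acceptors, yet the two values lie within the usual scatter of each other, so this one exchange at this position shows no measurable difference in this assay. No accompanying measurement says why these two groups give such similar numbers.

The compounds shown leave open whether an amine, a methoxy group or a carboxylic acid on the same aromatic carbon would give a value beyond the scatter, and so whether this position matters at all for the read-out. A single pair also cannot tell whether bromo and nitro would match in the same way at other places on the shared core, or alongside the two methyl groups carried by compound 2.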